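From Isopropoxy to Fluoro at the Cytotoxicity Limit

The source may report more compounds than this note shows. Statements on the series, on what has been measured and on what is new or still open speak of the compounds shown alone.

Compound 1 (`COc1ccc(C2=C(c3cc(OC)c(OC)c(OC)c3)C(=O)C(OC(C)=O)C2)cc1OC(C)C`) gives > 100 ug/mL in an ADME assay on L132 cells (Homo sapiens) for cytotoxicity, read by MTT assay, with a stated time of 72 h (on this read-out higher numbers stand for weaker inhibition and lower numbers for stronger inhibition), as a limit of the assay and not a number. Compound 2 (`COc1cc(C2=C(c3cc(C)c(OC)c(C)c3)C(O)CC2=O)cc(OC)c1OC`) gives > 100 ug/mL as a limit too. Compound 1 therefore stands with the limit of > 100 ug/mL in this assay, at which 2 of the 2 values shown sit, and has no exact number to compare. Compound 3 (`COc1ccc(C2=C(c3cc(OC)c(OC)c(OC)c3)C(=O)C(OC(C)=O)C2)cc1F`) carries fluoro in place of isopropoxy on an aromatic carbon. Among the compounds with values here, no measured step covers this change, so in this assay the expected step stays within the scatter, in no particular direction. The estimated change is a number no higher from compound 1 to compound 3 (the limit leaves the size open) on this reading. For compound 3 the expected value is 100 ug/mL with an estimated range from 45 ug/mL to 200 ug/mL and a report at the limit is likely.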

Compound 3, half-maximal inhibitory concentration: < 1 ug/mL
Compound 3 was reported as a limit; the forecaster's own chance of this, stated with the estimate: 75%; middle value at least 100-fold (2.00 log units) away from the limit.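

In this assay, this single aromatic position proves decisive: fluoro in place of isopropoxy gives an at least 100-fold lower number from compound 1 to compound 3 (2.00 log units; beyond the scatter), a sensitivity to the group at this position that the two earlier compounds, both at the upper limit, could not reveal. Compound 3 stands alone at the low end of the assay, and its value is also a limit: the limit of < 1 ug/mL in this assay, at which 1 of the 3 values shown sits.

From the compounds shown here alone, both ends of the step are limits, and its true size stays open. Also open, going by these compounds, is whether a chloro group or an amine at this position would behave like fluoro or like isopropoxy.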